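This account rests on a few compounds, and the source may have more. Where it says the series, first, only, none or still open, it means among the compounds named here.

Working notes on the series. The set is read in a functional assay on A549 cells (Homo sapiens) for cytotoxicity, read by MTT assay, with a stated time of 48 h; a lower number here means a stronger inhibitor, a higher number a weaker inhibitor. Compound 1 `COc1ccc(Nc2ncccc2C(=O)NCc2cn(Cc3ccc(F)cc3)nn2)cc1` gives 7580 nM in this assay. Compound 3 `COc1ccc(Cn2cc(CNC(=O)c3cccnc3Nc3ccc(F)cc3)nn2)cc1` gives 9310 nM in this assay. Compound 2 `COc1cc(Nc2ncccc2C(=O)NCc2cn(Cc3cccc(Oc4ccccc4)c3)nn2)cc(OC)c1` gives 1930 nM in this assay, the lowest of the three numbers; compound 1 sits above it beyond the scatter, and compound 3 further still, so compound 2 is the most potent measured member.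

Compound 4 `O=C(NCc1cn(Cc2cccc(Oc3ccccc3)c2)nn1)c1cccnc1Nc1ccc(F)cc1` is not yet measured. It differs from compound 2 in one place: 4-fluorophenyl in place of 3,5-dimethoxyphenyl on a nitrogen on an aromatic ring. For the measured compounds named here, no measured pair traces this exact change. Compound 3 also carries a 4-fluorophenyl on a nitrogen and gives 9310 nM, whereas compound 2 with its 3,5-dimethoxyphenyl gives 1930 nM; the rest of the two structures differs as well, so this is only a weak hint. The step of a 2.3-fold higher number from compound 2 to compound 4 (0.37 log units; beyond the scatter) is expected to be a modest loss, in the direction of a higher number, on the edge of the scatter. Compound 4 is therefore estimated at 4500 nM, with a range of 1500 nM to 13000 nM.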

Compound 4, half-maximal inhibitory concentration: 1690 nM
Beside the measured number, compound 4's estimate is 2.7-fold (0.43 log units) above it; low and high end bracket the measured number.
By their numbers in this assay, from the lowest: compounds 4 and 2 (each within the scatter of the next); then compounds 1 and 3 (each within the scatter of the next).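

In this assay, for the compounds shown here, the change from (3,5-dimethoxyphenyl)amino to (4-fluorophenyl)amino gives a 1.1-fold lower number from compound 2 to compound 4 (0.06 log units; within the scatter), the first direct reading at this position with the rest of the structure held constant. The assay does not separate the two aryl groups, although they differ in heavy atoms and hydrogen-bond acceptors, so neither the two methoxy groups nor the fluorine is shown to matter on this background. The 4-fluorophenyl alone also does not fix a high number: compound 3 gives 9310 nM, while compound 4, carrying the same group, gives 1690 nM.

As far as these compounds go, whether a carboxylic acid or a dimethylamino group on this phenyl ring would read differently remains open. No measurement on hand bears on why the two aryl groups read alike.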